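The compounds below may be only part of what the source reports. "The series", "measured", "known", "first", "only" and "open" are said of these compounds alone.

Measured in a functional assay on A549 cells (Homo sapiens) for inhibition, read by MTT assay, with a stated time of 48 h; a higher number here means a weaker inhibitor, a lower number a stronger inhibitor:
- Compound 1 `Brc1ccc2[nH]cc(C(c3ccccc3)c3c[nH]c4ccc(Br)cc34)c2c1`: 7500 nM
- Compound 2 `COc1cccc(C(c2c[nH]c3ccc(Br)cc23)c2c[nH]c3ccc(Br)cc23)c1OC`: 100000 nM
- Compound 3 `COc1ccc(C(c2c[nH]c3ccc(Br)cc23)c2c[nH]c3ccc(Br)cc23)c(OC)c1`: 100000 nM

Together with compound 2, compound 3 gives 100000 nM, the highest of the three numbers, which puts this pair at the weak end of the set.

The next structure, compound 4 `COc1ccc(OC)c(C(c2c[nH]c3ccc(Br)cc23)c2c[nH]c3ccc(Br)cc23)c1`, differs from compound 3 in one place: 2,5-dimethoxyphenyl in place of 2,4-dimethoxyphenyl on a saturated chain carbon bound to two aromatic carbons. A 2,5-dimethoxyphenyl takes the place of the 2,4-dimethoxyphenyl on a saturated chain carbon bound to two aromatic carbons. The two compounds have the same atoms, joined differently.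

Within the data shown here, three measured steps bear on this change. Putting a dimethoxyphenyl in place of phenyl gave two large steps, a 13-fold higher number from compound 1 to compound 2 (1.12 log units; beyond the scatter) and a 13-fold higher number from compound 1 to compound 3 (1.12 log units; beyond the scatter). Neither is a close match. Compound 4 also carries a dimethoxyphenyl. Among the measured compounds shown here, the nearest guide is the swap of one dimethoxyphenyl for another, no change at the digits printed from compound 2 to compound 3 (within the scatter), although it is only a single example.

On that basis, the estimated step in this assay is a 1.4-fold lower number from compound 3 to compound 4 (0.15 log units; within the scatter), with none expected beyond the scatter. Compound 4 is estimated at 70000 nM, with an expected range from 20000 nM to 150000 nM.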

Compound 4, half-maximal inhibitory concentration: 10000 nM
Estimate against measurement, compound 4: 7.0-fold (0.85 log units) above, and the stated range ends above it.
By their numbers in this assay, from the lowest: compounds 1 and 4 (each within the scatter of the next); then compounds 2 and 3 (each within the scatter of the next).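

In this assay, where the two methoxy groups sit on this ring now matters, something the earlier swap between the 2,3-dimethoxyphenyl and 2,4-dimethoxyphenyl compounds could not show, since that step gave no change at the digits printed. The 2,5-dimethoxyphenyl group on the saturated chain carbon separates itself from both of the other arrangements, with one step of the same size against each (a 10-fold lower number from compound 3 to compound 4 (1.00 log units; beyond the scatter); a 10-fold lower number from compound 2 to compound 4 (1.00 log units; beyond the scatter)). A dimethoxyphenyl group at this place therefore does not always come with the large penalty seen for compound 2 and compound 3, as compound 4 cannot be told apart from the plain phenyl compound (a 1.3-fold higher number from compound 1 to compound 4 (0.12 log units; within the scatter)), and no measurement at hand explains why this one arrangement behaves differently.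

Open, as far as these compounds go, is whether a single methoxy group, a hydroxyl or an amine on this ring would group with compound 1 and compound 4 or with compound 2 and compound 3. Also open, from the compounds shown here alone, is whether the difference between the 2,5-dimethoxyphenyl group and the other two arrangements would persist if a chlorine replaced the bromine on the shared core.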